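The source may hold more compounds than are shown below. What is called first, only, known or untested is meant among the compounds shown, and "the series" means these compounds.

Compound 1 `COc1ccc([C@H]2CC(=O)N(Cc3cccc(C#N)c3)C2)cc1OC1CCCC1`: > 10000 nM
Compound 2 `COc1ccc([C@H]2CC(=O)N(C(C)=O)C2)cc1OC1CCCC1`: > 10000 nM
Compound 3 `COc1ccc([C@H]2CC(=O)N(c3cccc(C#N)c3)C2)cc1OC1CCCC1`: > 10000 nM

Of the compounds shown here, three that share a common core have been tested in a functional assay on HEK293 cells (Homo sapiens) for cytotoxicity; a higher number here means that more compound is tolerated, a lower number that less compound is tolerated. Compound 1 reaches only a limit of the assay, > 10000 nM, and no number. Compound 2 likewise gives only a limit, > 10000 nM. Compound 3 gives > 10000 nM, again a limit rather than a measured number. Among the measured compounds shown here, all three values therefore sit together at the same point, as the limit of > 10000 nM in this assay, at which 3 of the 3 values shown sit, records, and no compound can be set above another.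

The steps among them are accordingly silent: a step that the two limits leave unreadable from compound 1 to compound 2, a step that the two limits leave unreadable from compound 1 to compound 3 and a step that the two limits leave unreadable from compound 2 to compound 3. Each exchanges one group on the amide-type nitrogen in the ring, yet the two limits leave the size of every step unreadable.

Compound 4 `COc1ccc([C@H]2CC(=O)N(c3ccc(C#N)cc3)C2)cc1OC1CCCC1` is the next compound in line. It differs from compound 1 by 4-cyanophenyl in place of 3-cyanobenzyl on an amide-type nitrogen in a ring. For the measured compounds named here, the closest measured step is the one from compound 1 to compound 3, where 3-cyanophenyl replaced 3-cyanobenzyl on the same nitrogen, and that step was unreadable. No readable step exists for this position, so no direction can be set in this assay; the expectation is that compound 4 also stays at the limit, with a step that the limit leaves unreadable from compound 1 to compound 4 expected from compound 1. Compound 4 is estimated at 15000 nM, with a range from 8000 nM to 40000 nM.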

Compound 4, half-maximal cytotoxic concentration: > 10000 nM
Compound 4 was reported as a limit (the forecaster's own chance of this, stated with the estimate: 85%); the middle value does not contradict the limit.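

Compound 4 gives > 10000 nM in this assay, a limit and not a number. Its steps from compound 1, compound 2 and compound 3 cannot be read, and no order can be set among the four compounds: the limit of > 10000 nM in this assay, at which 4 of the 4 values shown sit.

The compounds shown leave open whether any of these groups on the amide-type nitrogen in the ring would set one compound apart from another in this assay.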